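The source may report more compounds than this note shows. Statements on the series, on what has been measured and on what is new or still open speak of the compounds shown alone.

Three compounds have been measured in an ADME assay on EA.hy 926 cells (Homo sapiens) for inhibition, read by MTT assay, with a stated time of 72 h; on this read-out higher numbers stand for weaker inhibition and lower numbers for stronger inhibition:

- Compound 1 `COc1cc(/C=C/C(=O)/C=C(/C=C/c2ccc(OC(C)=O)c(OC)c2)NC2CCCCC2)ccc1OC(C)=O`: > 25000 nM
- Compound 2 `CCC(C)NC(=C\C(=O)/C=C/c1ccc(O)c(OC)c1)/C=C/c1ccc(O)c(OC)c1`: > 25000 nM
- Compound 3 `COc1cc(/C=C/C(=O)CC(=O)/C=C/c2ccc(OC(C)=O)c(OC)c2)ccc1OC(C)=O`: > 25000 nM

Each of these entries is a limit of the assay and not a number. Compound 2 therefore has no exact position on the scale, and it shares (the limit of > 25000 nM in this assay, at which 3 of the 3 values shown sit). Among the measured compounds shown here, the three compounds cannot be ranked, and no measured step is available to show how much a single structural change matters in this assay.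

The next compound is compound 4 `COc1cc(/C=C/C(=O)/C=C(/C=C/c2ccc(O)c(OC)c2)NC2CCCCC2)ccc1O`. It differs from compound 2 in one place, with cyclohexyl in place of sec-butyl on an amine nitrogen. The measured compounds give no direct scale for this exchange, so the expectation is cautious: no step beyond the usual scatter in this assay, and no firm direction. This expectation starts from compound 2, whose entry of > 25000 nM is a limit. Compound 4 is also expected to be reported quite possibly as a limit rather than as a number. The estimated change is a step that the limit leaves unreadable from compound 2 to compound 4. For compound 4, the estimated half-maximal inhibitory concentration is 30000 nM, with an expected range of 14000 nM to 60000 nM.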

Compound 4, half-maximal inhibitory concentration: > 25000 nM
Compound 4 was reported as a limit (the forecaster's own chance of this, stated with the estimate: 70%); the middle value lies beyond the limit too.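

In this assay compound 4 gives > 25000 nM, which is a limit and not a number. Compound 2 also stands at a limit, so no step can be read between compound 2 and compound 4. The compounds shown leave open whether exchanging sec-butyl for cyclohexyl changes the half-maximal inhibitory concentration at all, and every value remains at one point: the limit of > 25000 nM in this assay, at which 4 of the 4 values shown sit.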